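This account rests on a few compounds, and the source may have more. Where it says the series, first, only, none or still open, it means among the compounds named here.

Of the compounds shown here, three of a shared core have been measured in a physicochemical assay for lipophilicity; a higher number here means a more lipophilic compound, a lower number a more polar compound. Compound 1 `CC(C)(C)OC(=O)NC[C@H]1CC[C@H](CNC(=O)c2cc(N3CCC(CCN4CC(O)C4)CC3)nc3ccccc23)CC1` gives 3.6 in this assay, compound 3 `CC(C)(C)OC(=O)NC[C@H]1CC[C@H](CNC(=O)c2cc(-c3ccccc3)nc3[nH]ccc23)CC1` gives 4.7, and compound 2 `CC(C)(C)OC(=O)NC[C@H]1CC[C@H](CNC(=O)c2cc(-c3cn[nH]c3)nc3ccccc23)CC1` gives 3.5. Compound 2 stands at the lowest of the three numbers; the number of compound 1 lies within the scatter of it, while the number of compound 3 lies beyond the scatter above it. Compound 4 `Cc1noc(C)c1-c1cc(C(=O)NC[C@H]2CC[C@H](CNC(=O)OC(C)(C)C)CC2)c2ccccc2n1` has not yet been measured. It differs from compound 2 in one place: 3,5-dimethyl-1,2-oxazol-4-yl in place of 1H-pyrazol-4-yl on an aromatic carbon. Within the data shown here, no pair of measured compounds carries this same change, so no measured step can be read across to it. In this assay a moderate rise is expected, a number 0.70 log units higher from compound 2 to compound 4 (beyond the scatter). Compound 4 is therefore estimated at 4.2, with a range from 3.7 to 4.7.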

Compound 4, distribution coefficient: 5
For compound 4 the middle estimate is 0.80 log units below the measured one; the whole stated range lies below it.
By their numbers in this assay, from the lowest: compounds 2 and 1 (each within the scatter of the next); then compounds 3 and 4 (each within the scatter of the next).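

In this assay, 3,5-dimethyl-1,2-oxazol-4-yl in place of 1H-pyrazol-4-yl on this aromatic carbon next to the ring nitrogen gives a number 1.50 log units higher from compound 2 to compound 4 (beyond the scatter), so the group at this position can move the number well beyond the scatter. The change replaces a ring bearing a hydrogen-bond donor with a ring bearing none and adds two methyl groups. Nothing available explains the size of this step. Still open, on these data alone, is whether the two methyl groups or the change of ring accounts for the step. An unsubstituted 1,2-oxazol-4-yl group or a 1-methylpyrazol-4-yl group at this carbon could separate the two.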